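Swapping the Carbonyl Substituent of a Limit-Bound Compound

The source may report more compounds than this note shows. Statements on the series, on what has been measured and on what is new or still open speak of the compounds shown alone.

The measured compounds and their values:
compound 1 `CCN1CCc2c(sc(NC(=O)[C@@H]3CCCN3)c2C(N)=O)C1`; in a functional assay (strain AB) with Danio rerio as the target, read by microscopy, with a stated time of 1 h (a lower number here means that less compound is needed, a higher number that more compound is needed for the effect), compound 1 gives > 25000 nM, which is a limit of the assay and not a number.
compound 2 `CCN1CCc2c(sc(N)c2C(N)=O)C1`; in this assay compound 2 gives > 25000 nM, likewise a limit.
compound 3 `CC1CCc2nc(NC(=O)Nc3ccc(Cl)cc3)sc2C1`; in this assay compound 3 gives > 25000 nM, also a limit.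

Compound 1 therefore stands nowhere on a numerical scale: every value shown sits at the same limit (the limit of > 25000 nM in this assay, at which 3 of the 3 values shown sit). For the measured compounds named here, the only step between measured compounds, a step that the two limits leave unreadable from compound 1 to compound 2, cannot be read in size for the same reason.

Compound 4 `CCN1CCc2c(sc(NC(=O)CN3CCCCC3)c2C(N)=O)C1` differs from compound 1 in one place: (piperidin-1-yl)methyl in place of pyrrolidin-2-yl on a carbonyl carbon. Going by the values given here, the step from compound 1 to compound 2 is the only measured change touching this carbonyl substituent, and it leaves no readable size or direction. Among the compounds with values here, with no measured step pointing either way in this assay, compound 4 is expected to remain where compound 1 stands. Compound 4 is estimated at 25000 nM, with a range from 8000 nM to 80000 nM. The expected step from compound 1 to compound 4 is accordingly a number no higher from compound 1 to compound 4 (the limit leaves the size open).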

Compound 4, half-maximal effective concentration: > 25000 nM
Compound 4 ended at the assay's limit (the forecaster's own chance of this, stated with the estimate: 80%); the middle value lies on the limit itself.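

Compound 4, like compound 1, stands at a limit and not at a number, so no step from compound 1 to compound 4 can be read: the limit of > 25000 nM in this assay, at which 4 of the 4 values shown sit.

The compounds shown leave open how any carbonyl substituent on this core changes the half-maximal effective concentration in this assay.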